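The source may hold more compounds than are shown below. What is called first, only, known or untested is meant among the compounds shown, and "the series" means these compounds.

Compound 2 `N=C(N)NCCC[C@H](NC(=O)CN(c1nc(Cl)nc2[nH]cnc12)C1CC1)C(=O)O`: 18.4%
Compound 1 `O=C(CN(c1nc(Cl)nc2[nH]cnc12)C1CC1)NCC(=O)OCc1ccccc1`: 19%
Compound 3 `CC(C)[C@H](NC(=O)CN(c1nc(Cl)nc2[nH]cnc12)C1CC1)C(=O)OCc1ccccc1`: 23.6%

All three numbers come from a functional assay on the whole organism (Tail, strain ICR) with Mus musculus as the target, in the tail flick test, with a stated time of 90 min, at a dose of 12.5 umol/kg by the oral route; on this read-out higher numbers stand for a stronger effect at the one dose given and lower numbers for a weaker effect. Among them compound 2 holds the lowest number, with compound 1 nearest to it and compound 3 furthest from it, both gaps within the scatter. Compound 4 `NCCCC[C@H](NC(=O)CN(c1nc(Cl)nc2[nH]cnc12)C1CC1)C(=O)O` differs from compound 2 by a group of 2 heavy atoms (1 carbon, 1 nitrogen; no ring) in place of a group of 4 heavy atoms (1 carbon, 3 nitrogen; no ring), on a saturated chain carbon, four bonds along the chain from an amide-type nitrogen and a carbonyl carbon. Among the compounds with values here, the one measured step, a number 4.6 percentage points higher from compound 1 to compound 3 (within the scatter), concerns a different place on the chain and is itself within the scatter, so no measured step bears directly on this change. A step of no size beyond the scatter is therefore expected, a number 0.4 percentage points lower from compound 2 to compound 4 (within the scatter). Compound 4 is estimated at 18%, with a range from 8% to 30%.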

Compound 4, a percentage reported as activity, at one dose (the size of the read-out at that dose, not a potency): 22%
The estimate for compound 4 lay 4 percentage points below the measured number, and the stated range covers the measured number.
By their numbers in this assay, from the lowest: compounds 2, 1, 4 and 3 (each within the scatter of the next).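

In this assay, within the data shown here, aminomethyl in place of the group of 4 heavy atoms on this saturated chain carbon gives a number 3.6 percentage points higher from compound 2 to compound 4 (within the scatter) and is the first measured change at this position. The group that leaves holds 1 carbon, 3 nitrogen and 1 double bond outside aromatic rings, and aminomethyl holds 1 carbon and 1 nitrogen, yet the read-out at the one dose does not separate the two compounds. No measurement here offers an explanation for the step. Open, going by these compounds, is whether a carboxylic acid or a longer chain ending in an amine on this carbon would give a step beyond the scatter. Also open, on these data alone, is whether aminomethyl gives the same result with a benzyl ester in place of the free carboxylic acid.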